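This account rests on a few compounds, and the source may have more. Where it says the series, first, only, none or still open, it means among the compounds named here.

The measured compounds are:
compound 1, `O=C(Nc1ccc(Cl)cc1)Nc1cccc(CNc2nccnc2Cl)c1`, giving 8350 nM;
compound 2, `CC(C)(C)c1ccc(NC(=O)Nc2cccc(CNc3nccnc3Cl)c2)cc1`, giving 7550 nM;
compound 3, `CN(C)c1ccc(NC(=O)Nc2cccc(CNc3nccnc3Cl)c2)cc1`, giving > 40000 nM.

In a functional assay on HepG2 cells (Homo sapiens) for antiproliferative activity, read by MTT assay, with a stated time of 48 h (on this read-out higher numbers stand for weaker inhibition and lower numbers for stronger inhibition), compound 1 and compound 2 sit close together, the difference between them being a 1.1-fold lower number from compound 1 to compound 2 (0.04 log units; within the scatter). Compound 3 stands apart: its result in this assay is only a limit, > 40000 nM, so no number is known for it. Among the compounds with values here, it is the one compound sitting at the limit of > 40000 nM in this assay, at which 1 of the 3 values shown sits. The steps leading to it are an at least 4.7-fold higher number from compound 1 to compound 3 (0.68 log units; beyond the scatter) and an at least 5.2-fold higher number from compound 2 to compound 3 (0.72 log units; beyond the scatter), both the same kind of move, dimethylamino entering on an aromatic carbon, and both weakening.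

Compound 4, `O=C(Nc1ccc(C(F)(F)F)cc1)Nc1cccc(CNc2nccnc2Cl)c1`, is the next compound to be measured in this assay. It differs from compound 3 by trifluoromethyl in place of dimethylamino on an aromatic carbon. The change removes the dimethylamino that accompanied the weakening in both measured steps and puts a trifluoromethyl there, a group without hydrogen-bond acceptors, like the chloro of compound 1 and the tert-butyl of compound 2. Compound 4 is therefore expected to return toward the level of compound 1 and compound 2, an expected step of an at least 5.0-fold lower number from compound 3 to compound 4 (0.69 log units; beyond the scatter). The estimate for compound 4 in this assay is 8000 nM, with a range from 3000 nM to 25000 nM.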

Compound 4, half-maximal inhibitory concentration: 5050 nM
For compound 4 the middle estimate is 1.6-fold (0.20 log units) above the measured one; measured number inside the range.
By their numbers in this assay, from the lowest: compounds 4, 2 and 1 (each within the scatter of the next). At a limit, above all of these: compound 3.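

In this assay, trifluoromethyl at this place, para to a large group, brings back the activity that is missing with dimethylamino, an at least 7.9-fold lower number from compound 3 to compound 4 (0.89 log units; beyond the scatter). Trifluoromethyl also falls in with chloro and tert-butyl, with a 1.5-fold lower number from compound 2 to compound 4 (0.17 log units; within the scatter) and a 1.7-fold lower number from compound 1 to compound 4 (0.22 log units; within the scatter), so these three groups cannot be told apart here, and among the four compounds only dimethylamino stands out. The size of the first step remains a bound and not a measured difference, because compound 3 rests on a limit: the limit of > 40000 nM in this assay, at which 1 of the 4 values shown sits.

As far as these compounds go, whether a plain amino group or a morpholine would weaken the result as dimethylamino does remains open, as does whether methoxy or nitrile would stay level with chloro, tert-butyl and trifluoromethyl. The four compounds also leave open whether any group at this place can give clearly stronger inhibition than these three.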